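Pyridin-2-yl in place of the fluorinated aryl amide

This account rests on a few compounds, and the source may have more. Where it says the series, first, only, none or still open, it means among the compounds named here.

Of the compounds shown here, two have been measured in a functional assay on HEK293 cells for agonist activity at D(4) dopamine receptor (Homo sapiens), read by FLIPR; on this read-out lower numbers stand for an effect already at smaller amounts and higher numbers for an effect only at larger amounts of compound. Compound 1, `Cc1cc(C(=O)NCN2CCC(c3cccc[n+]3[O-])CC2)ccc1F`, gives 50 nM in this assay, the lowest of the two numbers recorded. Compound 2, `Cc1ccc([N+](=O)[O-])cc1NC(=O)CN1CCC(c2cccc[n+]2[O-])CC1`, gives 134 nM in this assay, a higher number than compound 1 and beyond the usual scatter. Among the compounds with values here, no two measured compounds differ in one place only, so no measured step is available to guide the next prediction.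

Compound 3, `O=C(NCN1CCC(c2cccc[n+]2[O-])CC1)c1ccccn1`, has not yet been measured in this assay. Compared with compound 1 the change is pyridin-2-yl in place of 4-fluoro-3-methylphenyl on a carbonyl carbon. Within the data shown here, with no measured step of this kind to lean on, the expectation rests on the change alone; the estimated step is a 4.0-fold higher number from compound 1 to compound 3 (0.60 log units; beyond the scatter), toward higher numbers, beyond the scatter. Compound 3 is therefore expected to give about 200 nM in this assay, within a range from 60 nM to 700 nM.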

Compound 3, half-maximal effective concentration: 3150 nM
For compound 3 the middle estimate is 16-fold (1.20 log units) below the measured one; the measured number lies above the stated range.
By their numbers in this assay, from the lowest: compound 1; then compound 2; then compound 3.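

In this assay, within the data shown here, the group on this carbonyl carbon proves to matter greatly: pyridin-2-yl in place of 4-fluoro-3-methylphenyl gives a 63-fold higher number from compound 1 to compound 3 (1.80 log units; beyond the scatter) and is the first single-place change measured, a large step beyond the scatter. The change swaps a carbon-only aromatic ring for one with a hetero atom and a hydrogen-bond acceptor, and it also removes the fluoro and methyl substituents, so this one step cannot separate these differences. No measured evidence accounts for the size of the step.

A plain phenyl group on this carbonyl carbon would show whether the ring nitrogen or the lost fluoro and methyl substituents carry the step. A pyridin-3-yl group would show whether the placing of that nitrogen matters.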